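The compounds below may be only part of what the source reports. "The series", "measured", "known", "first", "only" and "open" are said of these compounds alone.

In a physicochemical assay for metabolic stability, read by HPLC, in phosphate buffer, at pH 7.4, tested at 10 uM (on this read-out higher numbers stand for a longer-lived compound and lower numbers for a shorter-lived compound), compound 2 `Cc1cccc(CNC(=O)n2cnc3ccccc32)c1` gives 0.933 h, the higher of the two numeric values in the series. Compound 3 `O=C(NCCCCc1ccccc1)n1nnc2ncccc21` gives 0.0333 h, lower than compound 2 by well beyond the scatter. Compound 1 `COc1nc2ccccc2n1C(=O)NCCCCc1ccccc1` is reported only as a limit, > 2 h.

Compound 4 `Cc1cccc(CNC(=O)n2c(N)nc3ccccc32)c1` departs from compound 2 by one change, amino in place of hydrogen on an aromatic carbon, between two ring nitrogen atoms. For the measured compounds named here, no measured pair isolates this change, so any expectation is weakly anchored. Going by the values given here, compound 1 is the only measured compound with a group other than hydrogen on that carbon, and its limit of > 2 h points upward, though its chain differs as well. A moderate rise in this assay is therefore expected, with the estimated step of a 2.7-fold higher number from compound 2 to compound 4 (0.43 log units; beyond the scatter). No change beyond the scatter remains a real possibility. For compound 4 the estimated half-life is 2.5 h, with an expected range of 0.7 h to 9 h.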

Compound 4, half-life: 0.183 h
For compound 4 the middle estimate is 14-fold (1.14 log units) above the measured one; measured number outside the range, below it.
By their numbers in this assay, from the lowest: compound 3; then compound 4; then compound 2. At a limit, above all of these: compound 1.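

In this assay, for the compounds shown here, amino in place of hydrogen on an aromatic carbon, between two ring nitrogen atoms, gives a 5.1-fold lower number from compound 2 to compound 4 (0.71 log units; beyond the scatter), the first step that isolates a single place. The half-life therefore responds to a change at this carbon, and a group other than hydrogen there does not by itself go with a longer-lived compound. Compound 1 also has a group other than hydrogen on that carbon, but it differs in its chain as well and is reported only as a limit: the limit of > 2 h in this assay, at which 1 of the 4 values shown sits.

Still open, on these data alone, is whether the direction of this step holds for other groups on the same carbon, such as methyl, chlorine or dimethylamino. Also open, as far as these compounds go, is whether the group of compound 1 would give a similar half-life on the chain of compound 2.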